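The compounds below may be only part of what the source reports. "The series", "measured", "known", "first", "only" and "open" are said of these compounds alone.

Measured so far:
compound 1 `Cc1cc(Cl)cc2nc(N3CCN(C)CC3)oc12` — 0.24
compound 2 `CN1CCN(c2nc3cc(Cl)cc(Cl)c3o2)CC1` — 0.14

Both values come from an assay on ileum (strain Hartley) with 5-hydroxytryptamine receptor 3A (Cavia porcellus) as the target; a higher number here means a larger maximal response, a lower number a smaller maximal response. Compound 2 cannot be set apart from compound 1 on these numbers: the step a number 0.10 lower from compound 1 to compound 2 (within the scatter) is within the scatter, so the two stand together at a low fraction of the reference response.

Compound 3 `CCc1cc(Cl)cc2nc(N3CCN(C)CC3)oc12` is not yet measured. It differs from compound 2 by ethyl in place of chloro on an aromatic carbon. Within the data shown here, the only measured step that bears on this is the one from compound 1 to compound 2, chloro in place of methyl, which gave a number 0.10 lower from compound 1 to compound 2 (within the scatter); the change to compound 3 runs the other way, an alkyl group again taking the place of chloro, though ethyl rather than methyl. A small rise at most is therefore expected, a number 0.10 higher from compound 2 to compound 3 (within the scatter), likely within the scatter. Compound 3 is estimated at 0.24 in this assay, with a range of 0.1 to 0.4.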

Compound 3, intrinsic activity: the largest response reached, as a fraction of the reference agonist's: 0.17
Beside the measured number, compound 3's estimate is 0.070 above it; low and high end bracket the measured number.
By their numbers in this assay, from the lowest: compounds 2, 3 and 1 (each within the scatter of the next).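

In this assay the position ortho to a fused ring now carries a second alkyl group, and the swap of chloro for ethyl gives a number 0.030 higher from compound 2 to compound 3 (within the scatter). Adding methyl on the saturated chain carbon bound to the aromatic carbon, which turns the methyl group of compound 1 into the ethyl group of compound 3, gives a number 0.070 lower from compound 1 to compound 3 (within the scatter). Methyl, ethyl and chloro at this position therefore cannot be told apart on intrinsic activity, and no evidence is available on what lies behind this. Going by these compounds, whether a longer chain such as butyl, a methoxy group or an amine at this position would give a step beyond the scatter remains open. On these data alone, it is also open how far the maximal response depends on the other chloro group or on the methylpiperazine, which all three compounds share.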